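This account rests on a few compounds, and the source may have more. Where it says the series, first, only, none or still open, it means among the compounds named here.

Compound 1 `CC#C[C@@H](Cc1nnn[nH]1)c1ccc(OCc2ccc3scc(-c4ccccc4C(F)(F)F)c3c2)cc1`: < 0.0667 h in an ADME assay on microsomes from liver (Homo sapiens) for metabolic stability; on this read-out lower numbers stand for a shorter-lived compound and higher numbers for a longer-lived compound; this is a limit of the assay, not a number.
Compound 2 `CC#C[C@@H](Cc1nnn[nH]1)c1ccc(OCc2ccc3scc(-c4ccc(OCCOC)cc4C)c3c2)cc1`: 0.717 h in this assay.
Compound 3 `CC#C[C@@H](Cc1nnn[nH]1)c1ccc(OCc2ccc3scc(-c4cccnc4C)c3c2)cc1`: < 0.0667 h in this assay ; this is also a limit of the assay, not a number.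

Among the compounds with values here, compound 2 thus stands as the only real number among the three; the other two sit at the limit of < 0.0667 h in this assay, at which 2 of the 3 values shown sit. Compound 4 `CC#C[C@@H](Cc1nnn[nH]1)c1ccc(OCc2ccc3scc(-c4ccc(OCCCS(C)(=O)=O)cc4C)c3c2)cc1` differs from compound 2 in one place: (methylsulfonyl)methyl in place of methoxy on a saturated chain carbon, two bonds along the chain from an oxygen on an aromatic ring. The two readable steps measured so far exchange the ring attached to the shared core: an at least 10-fold higher number from compound 1 to compound 2 (1.03 log units; beyond the scatter) and an at least 10-fold lower number from compound 2 to compound 3 (1.03 log units; beyond the scatter). Neither changes the chain altered here, so they give no direct guidance, and the change in compound 4 is expected to stay within the scatter: a 1.2-fold lower number from compound 2 to compound 4 (0.08 log units; within the scatter). Compound 4 is therefore estimated at 0.6 h, with a range from 0.25 h to 1.5 h.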

Compound 4, half-life: 1.28 h
Beside the measured number, compound 4's estimate is 2.1-fold (0.33 log units) below it, within the range that was stated.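

In this assay, 3-(methylsulfonyl)propoxy can stand in place of 2-methoxyethoxy without a readable shift: a 1.8-fold higher number from compound 2 to compound 4 (0.25 log units; within the scatter). The earlier readable steps all exchanged the ring on the shared core, whereas this one shows that the end of this chain accepts a clearly different group and the compound stays clear of the assay limit. Nothing shown here gives a measured property that would explain this result.

On these data alone, whether an amine or a carboxylic acid at the end of this chain would give a similar half-life remains open. So does the effect of a longer chain carrying the same methylsulfonyl group.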